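Methoxy to hydroxy in a diaryl urea pyrazole series

A few compounds are considered here, and "the series" means these few. Any claim that something is new, unique, unknown or untested is made for them only; others in the source may bear on it.

Measured compounds:
- compound 1 `COc1cc(-c2nn(-c3cccc(NC(=O)Nc4cc(C(F)(F)F)cc(C(F)(F)F)c4)c3)cc2-c2ccncc2)ccc1Cl`: 847 nM
- compound 2 `COc1cc(-c2nn(-c3cccc(NC(=O)Nc4ccc(Cl)c(Cl)c4)c3)cc2-c2ccncc2)ccc1Cl`: 937 nM
- compound 3 `O=C(Nc1cccc(-n2cc(-c3ccncc3)c(-c3ccc(Cl)c(O)c3)n2)c1)Nc1ccc(Cl)c(Cl)c1`: 3960 nM

All three were tested in a functional assay on COLO 205 cells (Homo sapiens) for inhibition, read by sulforhodamine B assay, with a stated time of 48 h; on this read-out lower numbers stand for stronger inhibition of growth and higher numbers for weaker inhibition of growth. Compound 1 and compound 2 give numbers within the scatter of each other; the difference between their two cores is not broken down here. Compound 2 and compound 3 differ by one change, (hydrogen in place of methyl on an oxygen on an aromatic ring), and that step reads a 4.2-fold higher number from compound 2 to compound 3 (0.63 log units; beyond the scatter).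

Compound 4 `O=C(Nc1cccc(-n2cc(-c3ccncc3)c(-c3ccc(Cl)c(O)c3)n2)c1)Nc1cc(C(F)(F)F)cc(C(F)(F)F)c1` is not yet measured. It differs from compound 1 by hydrogen in place of methyl on an oxygen on an aromatic ring, the same change as from compound 2 to compound 3, at a place described in the same words. If this change behaves as it did once before, a step of similar size is expected, a 4.1-fold higher number from compound 1 to compound 4 (0.62 log units; beyond the scatter), resting on the single precedent a 4.2-fold higher number from compound 2 to compound 3 (0.63 log units; beyond the scatter). Compound 4 is therefore estimated at 3500 nM in this assay, between 1500 nM and 8000 nM.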

Compound 4, concentration for 50% growth inhibition: 853 nM
Compound 4: middle estimate off by 4.1-fold (0.61 log units), on the high side; measured number outside the range, below it.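

In this assay, methoxy to hydroxy reads a 1.0-fold higher number from compound 1 to compound 4 (0.00 log units; within the scatter), so the larger step seen earlier does not carry over to this core. The same change gives two different readings on the two cores: the same change on two cores in this assay, a 4.2-fold higher number (0.63 log units; beyond the scatter) from compound 2 to compound 3 and a 1.0-fold higher number (0.00 log units; within the scatter) from compound 1 to compound 4, 4.2-fold (0.62 log units) apart, beyond the scatter of two such steps
The step therefore cannot be carried from one core to another in this series as a fixed number, but two pairs do not show which difference between the cores goes with the gap or what size of step a third core would give.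

Open, as far as these compounds go, is how an amine or a longer alkoxy chain in place of the methoxy would read on each core. Also open, from the compounds shown here alone, is whether the trifluoromethyl or the chloro substituents of the two cores govern the size of the step.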